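The source may report more compounds than this note shows. Statements on the series, on what has been measured and on what is new or still open speak of the compounds shown alone.

Measured compounds so far:
Compound 1 `COc1ccccc1-c1ncnc2c1ncn2C[C@@H]1C[C@H](O)c2ccccc21` gives > 200000 nM in an ADME assay on L1210/0 cells (Mus musculus) for cytotoxicity, with a stated time of 48 h (on this read-out higher numbers stand for weaker inhibition and lower numbers for stronger inhibition), which is a limit of the assay and not a number.
Compound 2 `Cc1ccc(C(=O)/C=C/c2cc(=O)[nH]c(=O)n2COCCO)cc1` gives 27900 nM in this assay.
Compound 3 `O=C(CI)NCc1cn([C@H]2C[C@H](O)[C@@H](CO)O2)c(=O)[nH]c1=O` gives 107000 nM in this assay.

Among the two actual numbers, compound 3 has the higher one and so the weaker cytotoxicity; compound 2, its nearest neighbour, sits lower by a gap beyond the usual scatter.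

Compound 4 `CC(C)(C)C#Cc1cn([C@H]2C[C@H](O)[C@@H](CO)O2)c(=O)[nH]c1=O` differs from compound 3 in a single place: 3,3-dimethylbut-1-yn-1-yl in place of (((iodomethyl)carbonyl)amino)methyl on an aromatic carbon. Within the data shown here, no pair of measured compounds shares this kind of change, so no measured step can guide the expectation. The step of a 1.4-fold higher number from compound 3 to compound 4 (0.15 log units; within the scatter) is expected to be small, within or just beyond the scatter, toward a higher number. For compound 4 the estimate in this assay is 150000 nM, within 50000 nM to 400000 nM.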

Compound 4, half-maximal inhibitory concentration: > 200000 nM
Compound 4 was reported as a limit; the forecaster's own chance of this, stated with the estimate: 40%; at least 1.3-fold (0.12 log units) between middle value and limit.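

In this assay compound 4 gives > 200000 nM, which is a limit of the assay and not a number. Replacing (((iodomethyl)carbonyl)amino)methyl with 3,3-dimethylbut-1-yn-1-yl on this aromatic carbon gives an at least 1.8-fold higher number from compound 3 to compound 4 (0.27 log units; that floor lies within the scatter), so this change brings no sign of stronger cytotoxicity, while the true size of the step stays hidden. The step can be read only as far as the top of the assay range: the limit of > 200000 nM in this assay, at which 2 of the 4 values shown sit.

As far as these compounds go, it remains open whether an amine or a carboxylic acid on this carbon would give a measurable number. It is also unclear how a shorter alkynyl chain would compare with either group.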